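Amine swap on two cores: cytotoxicity working notes

This account rests on a few compounds, and the source may have more. Where it says the series, first, only, none or still open, it means among the compounds named here.

Measured in a functional assay on HepG2 cells (Homo sapiens) for cytotoxicity, read by MTT assay, with a stated time of 48 h (on this read-out higher numbers stand for weaker inhibition and lower numbers for stronger inhibition), so far:
compound 1 `CCN(CC)Cc1ccc2c(=O)cc(-c3ccccc3Cl)oc2c1` gives 10700 nM
compound 2 `O=c1cc(-c2ccccc2Cl)oc2cc(CN3CCCCC3)ccc12` gives 3640 nM
compound 3 `CCN(CC)Cc1cc(Cl)cc2c(=O)cc(-c3ccccc3Cl)oc12` gives 7940 nM

Going by the values given here, the one counted step is a 2.9-fold lower number from compound 1 to compound 2 (0.47 log units; beyond the scatter), the change being (piperidin-1-yl in place of diethylamino on a saturated chain carbon bound to an aromatic carbon). Compound 3 stands on a different core from compound 1; the difference between the two cores is not broken down here, and their values lie within the scatter of each other.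

Compound 4 `O=c1cc(-c2ccccc2Cl)oc2c(CN3CCCCC3)cc(Cl)cc12` is not yet measured. It differs from compound 3 by piperidin-1-yl in place of diethylamino on a saturated chain carbon bound to an aromatic carbon, the same change as that from compound 1 to compound 2. Among the compounds with values here, for compound 4 a step of about a 2.3-fold lower number from compound 3 to compound 4 (0.36 log units; beyond the scatter) is expected in this assay, resting on the single earlier step of a 2.9-fold lower number from compound 1 to compound 2 (0.47 log units; beyond the scatter); with only one prior example the expectation is loose. Compound 4 is thus estimated at 3500 nM, with a likely range of 1800 nM to 7000 nM.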

Compound 4, half-maximal inhibitory concentration: 10700 nM
For compound 4 the middle estimate is 3.1-fold (0.49 log units) below the measured one; measured number above the stated range.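

In this assay, the swap of diethylamino for piperidin-1-yl on the second core gives a 1.3-fold higher number from compound 3 to compound 4 (0.13 log units; within the scatter), so the lower number seen on the first core does not recur. The two steps do not agree: the same change on two cores in this assay, a 2.9-fold lower number (0.47 log units; beyond the scatter) from compound 1 to compound 2 and a 1.3-fold higher number (0.13 log units; within the scatter) from compound 3 to compound 4, 4.0-fold (0.60 log units) apart, beyond the scatter of two such steps

The change therefore cannot be carried between these cores as a fixed step, though two pairs do not show which feature of the cores sets the gap, nor how the change would fall on a third core. Still open, from the compounds shown here alone, is whether other cyclic amines, such as pyrrolidin-1-yl or morpholin-4-yl, would follow the pattern of the first core or the second. Also open, going by these compounds, is whether a different amine would give a step beyond the scatter on the second core.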